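Amino acid side chains in the series: compound 3 to compound 4

The source may report more compounds than this note shows. Statements on the series, on what has been measured and on what is new or still open speak of the compounds shown alone.

Measured in a functional assay on K562 cells (Homo sapiens) for cytotoxicity, read by trypan blue exclusion, with a stated time of 96 h; on this read-out higher numbers stand for weaker inhibition and lower numbers for stronger inhibition:
- compound 1 `COc1cc(OC)c(/C=C/S(=O)(=O)Cc2ccc(OC)c([N+](=O)[O-])c2)c(OC)c1`: 2500 nM
- compound 2 `COC(=O)CNc1cc(CS(=O)(=O)/C=C/c2c(OC)cc(OC)cc2OC)ccc1OC`: 100 nM
- compound 3 `COc1cc(OC)c(/C=C/S(=O)(=O)Cc2ccc(OC)c(N[C@@H](C)C(=O)O)c2)c(OC)c1`: 15 nM

Compound 3 holds the lowest number of the three. The steps reaching it are a 170-fold lower number from compound 1 to compound 3 (2.22 log units; beyond the scatter) and a 6.7-fold lower number from compound 2 to compound 3 (0.82 log units; beyond the scatter), both beyond the scatter. Next comes compound 4 `COc1cc(OC)c(/C=C/S(=O)(=O)Cc2ccc(OC)c(NC(C(=O)O)c3ccccc3)c2)c(OC)c1`, with this change: carboxy(phenyl)methyl in place of 1-carboxyethyl on a nitrogen on an aromatic ring. In words, carboxy(phenyl)methyl stands in place of 1-carboxyethyl on a nitrogen on an aromatic ring.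

The closest evidence is a 6.7-fold lower number from compound 2 to compound 3 (0.82 log units; beyond the scatter), a modest step made on that same nitrogen. The larger 25-fold lower number from compound 1 to compound 2 (1.40 log units; beyond the scatter) replaces nitro and says little about this change. Among the compounds with values here, no measured compound has an aromatic ring in this group, so the direction is uncertain. Within the data shown here, with compound 3 at 15 nM, the lowest number so far, a modest rise in this assay is the more likely outcome. The expected step is a 2.7-fold higher number from compound 3 to compound 4 (0.43 log units; beyond the scatter). Compound 4 is estimated at 40 nM, with an expected range of 10 nM to 200 nM.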

Compound 4, half-maximal inhibitory concentration: 15 nM
For compound 4 the middle estimate is 2.7-fold (0.43 log units) above the measured one, and the stated range covers the measured number.
By their numbers in this assay, from the lowest: compounds 3 and 4 (each within the scatter of the next); then compound 2; then compound 1.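

In this assay, carboxy(phenyl)methyl in place of 1-carboxyethyl on a nitrogen on an aromatic ring gives no change at the digits printed from compound 3 to compound 4 (within the scatter). This nitrogen therefore accepts a six-membered aromatic ring of carbon only, with 10 heavy atoms entering for 5, and no step beyond the scatter results. The other new steps, a 6.7-fold lower number from compound 2 to compound 4 (0.82 log units; beyond the scatter) and a 170-fold lower number from compound 1 to compound 4 (2.22 log units; beyond the scatter), match those already printed for compound 3.

The compounds shown leave open whether a primary amide in place of the carboxylic acid, or a longer chain holding the phenyl ring further from the nitrogen, would fit as well, and compound 4, unlike compound 3, carries no defined stereocentre, so any difference between its mirror forms is also open. No measurement is at hand to explain why these two groups read alike.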